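A few compounds are considered here, and "the series" means these few. Any claim that something is new, unique, unknown or untested is made for them only; others in the source may bear on it.

Measured so far:
compound 1 `COCCCO/N=C/c1c(N)ncnc1Oc1ccc(NC(=O)C2(C(=O)Nc3ccc(F)cc3)CC2)cc1F` — 3.18
compound 2 `N/N=C/c1c(N)ncnc1Oc1ccc(NC(=O)C2(C(=O)Nc3ccc(F)cc3)CC2)cc1F` — 2.25

Going by the values given here, the series so far holds two compounds read in a physicochemical assay for lipophilicity, using the shake flask method; a lower number here means a more polar compound, a higher number a more lipophilic compound. Compound 2 has the lower of the two numbers; compound 1 stands a number 0.93 log units lower from compound 1 to compound 2 (beyond the scatter) away from it, the difference being beyond the scatter.

The next compound, compound 3 `Nc1ncnc(Oc2ccc(NC(=O)C3(C(=O)Nc4ccc(F)cc4)CC3)cc2F)c1/C=N/OCCCN1CCCC1`, has not yet been measured in this assay. Relative to compound 2 the change is 3-(pyrrolidin-1-yl)propoxy in place of amino on a double-bonded nitrogen.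

Among the compounds with values here, the only measured step that bears on this is the one between compound 1 and compound 2, a number 0.93 log units lower from compound 1 to compound 2 (beyond the scatter), which swapped the 3-methoxypropoxy on the double-bonded nitrogen for amino. Within the data shown here, compound 3 takes the opposite direction from compound 2, again putting an alkoxy chain of nine heavy atoms on that nitrogen, but with a five-membered ring holding a nitrogen at its end instead of a methoxy, for which no measured step exists. A rise from compound 2 is therefore expected in this assay, but smaller than the full reverse of the known step, giving an expected a number 0.35 log units higher from compound 2 to compound 3 (beyond the scatter). Compound 3 is estimated at 2.6, with a range of 1.8 to 3.4.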

Compound 3, partition coefficient: 3.82
The estimate for compound 3 lay 1.22 log units below the measured number, and the stated range ends below it.
By their numbers in this assay, from the lowest: compound 2; then compound 1; then compound 3.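

Until now, this position on the double-bonded nitrogen had shown only the fall on going to amino, a number 0.93 log units lower from compound 1 to compound 2 (beyond the scatter), in this assay. The 3-(pyrrolidin-1-yl)propoxy group now shows a rise of a larger printed size, a number 1.57 log units higher from compound 2 to compound 3 (beyond the scatter), and the series no longer spans only the range between an amino and a methoxy-ended chain, since compound 3 stands highest of the three. The comparison of the two chains adds that the chain end alone moves the number in this assay, with pyrrolidin-1-yl in place of methoxy on a saturated chain carbon giving a number 0.64 log units higher from compound 1 to compound 3 (beyond the scatter), while nothing available accounts for the direction or the size of either new step.

As far as these compounds go, it remains open whether a morpholine ring or a dimethylamino group at the chain end would read like the pyrrolidin-1-yl end, and whether a shorter or longer chain would keep the same step. From the compounds shown here alone, the reading of a simple hydroxy group on the double-bonded nitrogen, set against amino and the two chains, is also open.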